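A few compounds are considered here, and "the series" means these few. Any claim that something is new, unique, unknown or untested is made for them only; others in the source may bear on it.

Measured compounds:
- compound 1, `O=C(NCc1cccc(Cn2cnc3ccccc32)c1)c1cc2ccccc2o1`, 413 nM in an assay for inhibition of Indoleamine 2,3-dioxygenase 1 (Homo sapiens), read by HPLC, with a stated time of 48 h; on this read-out higher numbers stand for weaker inhibition and lower numbers for stronger inhibition
- compound 2, `Cc1ccc2[nH]c(C(=O)NCc3cccc(Cn4cnc5ccccc54)c3)cc2c1`, 636 nM in this assay

Among the compounds with values here, compound 2 and compound 1 are the only two compounds measured, and their values lie within the scatter of each other: the step of a 1.5-fold higher number from compound 1 to compound 2 (0.19 log units; within the scatter) is too small to count as a real difference. Compound 3, `O=C(NCc1cccc(Cn2cnc3ccccc32)c1)c1cc2cc(O)ccc2[nH]1`, has not yet been measured. It differs from compound 2 in one place: hydroxy in place of methyl on an aromatic carbon. Within the data shown here, the single measured step, from compound 1 to compound 2, swaps one fused ring system for another and does not touch the substituent changed here, so no measured step speaks directly to a methyl-to-hydroxy exchange. With nothing to push the number either way, the expected step of a 1.1-fold lower number from compound 2 to compound 3 (0.03 log units; within the scatter) is no change beyond the scatter. For compound 3 the estimate is 600 nM, within a range from 200 nM to 1800 nM.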

Compound 3, half-maximal inhibitory concentration: 781 nM
The estimate for compound 3 lay 1.3-fold (0.11 log units) below the measured number; measured number inside the range.
By their numbers in this assay, from the lowest: compounds 1, 2 and 3 (each within the scatter of the next).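

Placing hydroxy instead of methyl on this aromatic carbon, which brings in a hydrogen-bond donor and a hydrogen-bond acceptor, gives a 1.2-fold higher number from compound 2 to compound 3 (0.09 log units; within the scatter) in this assay, so the two groups cannot be told apart here. The comparison with the other ring system, 5-hydroxy-1H-indol-2-yl in place of 1-benzofuran-2-yl on the carbonyl carbon, gives a 1.9-fold higher number from compound 1 to compound 3 (0.28 log units; within the scatter) and likewise shows no real difference. Nothing measured on these compounds offers an explanation for this result.

Methyl and hydroxy are the only groups shown at this position, so it remains open whether an amine, a carboxylic acid or a longer chain such as butoxy would give a number beyond the scatter. Also open, as far as these compounds go, is whether any group placed on this carbon can give stronger inhibition than the shared core already provides.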